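The source may report more compounds than this note shows. Statements on the series, on what has been measured and on what is new or still open speak of the compounds shown alone.

Compound 1 `O=S(=O)(/C=C/c1ccc(Cl)cc1)Cc1ccc(Nc2ncnc3ccccc23)cc1` gives 43000 nM in a functional assay on PC-3 cells (Homo sapiens); a higher number here means a weaker inhibitor of growth, a lower number a stronger inhibitor of growth. Compound 2 `O=S(=O)(/C=C/c1ccc(O)cc1)Cc1ccc(Nc2ncnc3ccccc23)cc1` carries hydroxy in place of chloro on an aromatic carbon and gives 14000 nM in this assay; the step is a 3.1-fold lower number from compound 1 to compound 2 (0.49 log units; beyond the scatter). Compound 3 `O=S(=O)(/C=C/c1ccc(Cl)cc1)Cc1ccc(Nc2ncnc3ccc(Br)cc23)cc1` differs from compound 1 in its core by bromo in place of hydrogen on an aromatic carbon; in this assay compound 3 gives 2000 nM. The step is a 22-fold lower number from compound 1 to compound 3 (1.33 log units; beyond the scatter), and compound 3 shows the lowest number of the three. Compound 4 `O=S(=O)(/C=C/c1ccc(O)cc1)Cc1ccc(Nc2ncnc3ccc(Br)cc23)cc1` has not yet been measured. It differs from compound 3 by hydroxy in place of chloro on an aromatic carbon, the same change as from compound 1 to compound 2, here made on the core of compound 3. Because the earlier step of a 3.1-fold lower number from compound 1 to compound 2 (0.49 log units; beyond the scatter) was modest, a step of similar size, a 3.1-fold lower number from compound 3 to compound 4 (0.49 log units; beyond the scatter), is expected in this assay; this rests on that single precedent only. Compound 4 is accordingly estimated at 650 nM, with 250 nM to 1700 nM as the expected range.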

Compound 4, concentration for 50% growth inhibition: 42000 nM
Estimate against measurement, compound 4: 65-fold (1.81 log units) below; measured number above the stated range.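

In this assay, hydroxy in place of chloro gives a 21-fold higher number from compound 3 to compound 4 (1.32 log units; beyond the scatter) on the bromo-bearing core, opposite in direction to the step on the core of compound 1: the same change on two cores in this assay, a 3.1-fold lower number (0.49 log units; beyond the scatter) from compound 1 to compound 2 and a 21-fold higher number (1.32 log units; beyond the scatter) from compound 3 to compound 4, 65-fold (1.81 log units) apart, beyond the scatter of two such steps. Bromo in place of hydrogen likewise gives a 3.0-fold higher number from compound 2 to compound 4 (0.48 log units; beyond the scatter) where hydroxy is present, opposite in direction to its step where chloro is present: the same change on two cores in this assay, a 22-fold lower number (1.33 log units; beyond the scatter) from compound 1 to compound 3 and a 3.0-fold higher number (0.48 log units; beyond the scatter) from compound 2 to compound 4, 65-fold (1.81 log units) apart, beyond the scatter of two such steps. Neither step therefore carries over between these cores, and the two changes do not add up across these four compounds, but the data do not show why or whether this extends to other cores.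

From the compounds shown here alone, it remains open whether an amine or a methoxy group in place of hydroxy would show the same reversal. Going by these compounds, it is also open whether chloro in place of bromo on the core would behave like bromo.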